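Removing one methyl from the chain of compound 2

The compounds below may be only part of what the source reports. "The series", "measured", "known", "first", "only" and "open" are said of these compounds alone.

In a functional assay (plasma) with Oryctolagus cuniculus as the target (a higher number here means a weaker inhibitor, a lower number a stronger inhibitor), compound 1 `Cc1nc2cnccc2n1C1CCN(C(=O)CC(c2ccccc2)c2ccccc2)CC1` gives 100 nM, compound 2 `Cc1nc2cnccc2n1CC1CCN(C(=O)CC(C)c2ccccc2)CC1` gives 12 nM and compound 3 `Cc1nc2cnccc2n1CC1CCN(S(=O)(=O)CC(C)(C)c2ccccc2)CC1` gives 6.2 nM. Compound 2 therefore sits within the scatter of compound 3, while its number is lower than that of compound 1 by a margin beyond the scatter.

Compound 4 `Cc1nc2cnccc2n1CC1CCN(C(=O)CCc2ccccc2)CC1` has not yet been measured. It departs from compound 2 by a single change: hydrogen in place of methyl on a saturated chain carbon bound to an aromatic carbon and a saturated chain carbon. The same difference reads as 2-phenylpropyl to phenethyl.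

Among the compounds with values here, no measured pair of compounds isolates this change, so the expectation is a cautious one, anchored on compound 2 at 12 nM. A small move toward a higher number in this assay is expected, and the estimated 1.7-fold higher number from compound 2 to compound 4 (0.22 log units; within the scatter) would not clearly leave the scatter. The expected value for compound 4 is 20 nM, with an estimated range from 6 nM to 70 nM.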

Compound 4, half-maximal inhibitory concentration: 60 nM
For compound 4 the middle estimate is 3.0-fold (0.48 log units) below the measured one; the range from low to high includes it.
By their numbers in this assay, from the lowest: compounds 3 and 2 (each within the scatter of the next); then compounds 4 and 1 (each within the scatter of the next).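

In this assay, the methyl on a saturated chain carbon bound to an aromatic carbon and a saturated chain carbon proves to matter: replacing it with hydrogen, which turns 2-phenylpropyl into phenethyl, brings a 5.0-fold higher number from compound 2 to compound 4 (0.70 log units; beyond the scatter) and gives the series its first reading of a single change. The loss of one carbon, with no ring, hydrogen-bond donor, hydrogen-bond acceptor or net charge entering or leaving, is thus enough to carry the number beyond the scatter. Nothing available accounts for the size of this step.

From the compounds shown here alone, whether an ethyl group, a hydroxyl or a fluorine at this same carbon would keep the number of compound 2, or improve on it, remains open. So does whether the methyl has a similar effect on other chains attached to the shared core.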